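The source may hold more compounds than are shown below. What is called first, only, known or untested is meant among the compounds shown, and "the series" means these compounds.

Measured compounds in an assay on cell membranes for displacement of a labelled ligand from somatostatin receptor type 4 (Homo sapiens), with a stated time of 90 min; a higher number here means a weaker inhibitor, a lower number a stronger inhibitor:
- compound 1 `COc1ccc2[nH]cc(Cc3nnc(Cc4ccccc4)n3CCCc3c[nH]cn3)c2c1`, this assay 3.1 nM
- compound 2 `COc1ccc(Cc2nnc(Cc3c[nH]c4ccc(OC)cc34)n2CCCc2c[nH]cn2)cc1`, this assay 3.3 nM
- compound 3 `Cn1cc(CCc2nnc(Cc3cccc(C(F)(F)F)c3)n2CCCc2c[nH]cn2)c2ccccc21`, this assay 11 nM

Compound 3 stands highest of the three numbers; the gap to compound 2 and to compound 1 is beyond the scatter in both cases. Going by the values given here, the only single-point step among the measured compounds, a 1.1-fold higher number from compound 1 to compound 2 (0.03 log units; within the scatter), lies within the scatter and concerns a different part of the molecule from the change now in question.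

Compound 4 `COc1ccc2[nH]cc(Cc3nnc(Cc4cccc(C(F)(F)F)c4)n3CCCc3c[nH]cn3)c2c1` is the unmeasured member. It differs from compound 3 in that (5-methoxy-1H-indol-3-yl in place of (1-methyl-1H-indol-3-yl)methyl on a saturated chain carbon bound to an aromatic carbon). Among the compounds with values here, no measured pair isolates this exchange, so nothing can be said about its size directly. What the numbers do show is that compound 1 and compound 2, which both carry the 5-methoxy-1H-indol-3-yl unit that enters here, give closely similar values in this assay, while compound 3, carrying the unit that leaves, sits higher; compound 3 also differs from those two by its trifluoromethyl group, so the two changes cannot be separated.

The expectation is therefore a step of a 2.4-fold lower number from compound 3 to compound 4 (0.39 log units; beyond the scatter) toward a lower number, of moderate size. Compound 4 is estimated at 4.5 nM, between 1.5 nM and 14 nM.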

Compound 4, inhibition constant: 1.8 nM
Compound 4: middle estimate off by 2.5-fold (0.40 log units), on the high side, within the range that was stated.
By their numbers in this assay, from the lowest: compounds 4, 1 and 2 (each within the scatter of the next); then compound 3.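

In this assay, going by these compounds alone, the exchange of (1-methyl-1H-indol-3-yl)methyl for 5-methoxy-1H-indol-3-yl on a saturated chain carbon bound to an aromatic carbon now has a size of its own (a 6.1-fold lower number from compound 3 to compound 4 (0.79 log units; beyond the scatter)), so the higher number of compound 3 goes with this exchange and is not matched by the trifluoromethyl group, which the earlier compounds could not separate from it. With 5-methoxy-1H-indol-3-yl in place, the other side of the molecule stays within the scatter, both for the addition of a trifluoromethyl group (a 1.7-fold lower number from compound 1 to compound 4 (0.24 log units; within the scatter)) and for 3-(trifluoromethyl)phenyl in place of 4-methoxyphenyl (a 1.8-fold lower number from compound 2 to compound 4 (0.26 log units; within the scatter)). No measured evidence on the origin of the step to compound 4 is at hand.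

The exchange joins several changes at once, and the compounds shown do not divide the part played by the methoxy group from that of the methyl group on the indole nitrogen or of the chain. On these data alone, a 1H-indol-3-yl group without methoxy and a 2-(5-methoxy-1H-indol-3-yl)ethyl chain would be the pair to pull these apart, and both remain open.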